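Pyridin-3-yl for pyridin-2-yl on compound 3

The source may report more compounds than this note shows. Statements on the series, on what has been measured and on what is new or still open speak of the compounds shown alone.

In a functional assay on ovarian cells (Homo sapiens) for antiproliferative activity (a lower number here means a stronger inhibitor of growth, a higher number a weaker inhibitor of growth), compound 1 `Cc1cn2c(/C=N/NC(=N)N)c(-c3ccncc3)nc2s1` gives 34700 nM and compound 2 `Cc1cn2c(/C=N/NC(=N)N)c(-c3cccnc3)nc2s1` gives 36300 nM while compound 3 `N=C(N)N/N=C/c1c(-c2ccccn2)nc2sc(Cl)cn12` gives 14500 nM as the lowest of the three numbers, beyond the scatter from both others. The change pyridin-3-yl in place of pyridin-2-yl on an aromatic carbon leads to compound 4 `N=C(N)N/N=C/c1c(-c2cccnc2)nc2sc(Cl)cn12` and puts pyridin-3-yl in place of pyridin-2-yl on an aromatic carbon. Among the compounds with values here, the only measured step that bears on it is a 1.0-fold higher number from compound 1 to compound 2 (0.02 log units; within the scatter) and that step has pyridin-3-yl in place of pyridin-4-yl. Within the data shown here, no step away from pyridin-2-yl has been measured, so the evidence is indirect. No change beyond the scatter is expected, and the estimated step is a 1.3-fold higher number from compound 3 to compound 4 (0.12 log units; within the scatter) in the direction of a higher number. Compound 4 is estimated at 19000 nM with 9000 nM to 40000 nM as the expected range.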

Compound 4, concentration for total growth inhibition: 36300 nM
Estimate against measurement, compound 4: 1.9-fold (0.28 log units) below; the measured number falls inside the stated range.
By their numbers in this assay, from the lowest: compound 3; then compounds 1, 2 and 4 (each within the scatter of the next).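

In this assay, within the data shown here, pyridin-3-yl in place of pyridin-2-yl on this aromatic carbon gives a 2.5-fold higher number from compound 3 to compound 4 (0.40 log units; beyond the scatter), the first step at this position beyond the scatter. Among these compounds, with pyridin-3-yl held fixed, chloro in place of methyl gives no change at the digits printed from compound 2 to compound 4 (within the scatter), so that swap shows no effect on this pair. Nothing available accounts for the difference between pyridin-2-yl and pyridin-3-yl.

Going by these compounds, whether pyridin-2-yl keeps its lower number with methyl in place of chloro remains open. So does the effect of an amine on the pyridine ring, or of a plain phenyl in its place.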